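Sulfated sugar amides: removing a chain sulfate for phenyl

This account rests on a few compounds, and the source may have more. Where it says the series, first, only, none or still open, it means among the compounds named here.

Working notes on a short series of sulfated monosaccharide amides tested in an assay on isolated protein for binding affinity to fibroblast growth factor 1 (Homo sapiens), read by surface plasmon resonance; a higher number here means weaker binding, a lower number tighter binding. Compound 1, `CO[C@H]1O[C@H](CNC(=O)CN(CCOS(=O)(=O)O)C(C)=O)[C@@H](OS(=O)(=O)O)[C@H](OS(=O)(=O)O)[C@@H]1OS(=O)(=O)O`, gives 95000 nM and stands second highest of the three numbers recorded so far. Compound 2, `CCN(CC(=O)NCCO[C@H]1O[C@H](COS(=O)(=O)O)[C@@H](OS(=O)(=O)O)[C@H](OS(=O)(=O)O)[C@@H]1OS(=O)(=O)O)C(=O)CCCCCCCCCOS(=O)(=O)O`, carries a further (sulfooxy) group on a long chain and gives 20000 nM, a lower number than compound 1 beyond the usual scatter. Compound 3, `CCN(CC(=O)NC[C@H]1O[C@H](OC)[C@@H](OS(=O)(=O)O)[C@@H](OS(=O)(=O)O)[C@@H]1OS(=O)(=O)O)C(=O)CCCc1ccccc1`, bears a phenyl on its side chain in place of any chain sulfate and gives 500000 nM, the highest number of the three.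

Compound 4, `CO[C@H]1O[C@H](CNC(=O)CN(Cc2ccccc2)C(C)=O)[C@@H](OS(=O)(=O)O)[C@H](OS(=O)(=O)O)[C@@H]1OS(=O)(=O)O`, has not yet been measured. It differs from compound 1 by phenyl in place of (sulfooxy)methyl on a saturated chain carbon bound to an amide-type nitrogen. Among the measured compounds shown here, no measured pair shows this exact change, so the size of the step rests on what compounds 2 and 3 show: the chain sulfate of compound 2 goes with the lowest number, the phenyl of compound 3 with the highest. The expectation is therefore a weaker binding for compound 4, with a step of a 2.6-fold higher number from compound 1 to compound 4 (0.42 log units; beyond the scatter) beyond the scatter. For compound 4 the estimate in this assay is 250000 nM, within a range from 90000 nM to 700000 nM.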

Compound 4, dissociation constant: 140000 nM
For compound 4 the middle estimate is 1.8-fold (0.25 log units) above the measured one, within the range that was stated.
By their numbers in this assay, from the lowest: compound 2; then compounds 1 and 4 (each within the scatter of the next); then compound 3.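

Among the compounds shown here, this is the first pair that differs in one place, so the chain sulfate can be read on its own. In this assay, phenyl in place of (sulfooxy)methyl on a saturated chain carbon bound to an amide-type nitrogen gives a 1.5-fold higher number from compound 1 to compound 4 (0.17 log units; within the scatter), so this pair does not separate the two groups, although the leaving group has 1 hydrogen-bond donor and 3 hydrogen-bond acceptors and the entering group has 0 of each. Nothing on hand accounts for this result.

On these data alone, whether a carboxylic acid or an amine at this place would give a number beyond the scatter of compound 1 stays open. So does whether a longer chain ending in the sulfate, or a longer chain ending in phenyl, would separate from compound 1 or compound 4.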